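This account rests on a few compounds, and the source may have more. Where it says the series, first, only, none or still open, it means among the compounds named here.

Compound 1 `O=C1Nc2ccc(Br)cc2/C1=N/NC(=S)Nc1ccc(Cl)cc1` and compound 2 `Cc1ccc(NC(=S)N/N=C2\C(=O)Nc3ccc(Br)cc32)cc1` share one core, while compound 3 `O=C1/C(=N\NC(=S)Nc2ccc(Cl)cc2)c2cc(F)ccc2N1Cc1ccc(F)cc1` and compound 4 `Cc1ccc(NC(=S)N/N=C2\C(=O)N(Cc3ccc(F)cc3)c3ccc(F)cc32)cc1` share another; how the two cores differ is not broken down here. In a functional assay on CCRF-CEM cells (Homo sapiens), with a stated time of 72 h (on this read-out lower numbers stand for stronger inhibition and higher numbers for weaker inhibition), compound 1 gives 61000 nM, and compound 2 gives 6800 nM. Among the compounds with values here, the single change between them, (methyl in place of chloro on an aromatic carbon), produced a 9.0-fold lower number from compound 1 to compound 2 (0.95 log units; beyond the scatter). In this assay compound 3 gives 56000 nM, a number that sits within the scatter of the value of compound 1, so nothing can be said about an order between those two; against compound 2 the gap is beyond the scatter.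

Compound 4 carries the same change on the second core, (methyl in place of chloro on an aromatic carbon), which sits on an aromatic carbon of a six-membered aromatic ring of carbon only, para to a large group, in both pairs. Within the data shown here, because the only precedent for this change is a 9.0-fold lower number from compound 1 to compound 2 (0.95 log units; beyond the scatter), the step from compound 3 to compound 4 is expected to run in the same direction and at roughly the same size, a 7.0-fold lower number from compound 3 to compound 4 (0.85 log units; beyond the scatter), although a single precedent on a different core leaves the size uncertain. In this assay compound 4 is therefore estimated at 8000 nM, with the likely range running from 2500 nM to 25000 nM.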

Compound 4, half-maximal inhibitory concentration: 2500 nM
The estimate for compound 4 lay 3.2-fold (0.51 log units) above the measured number; the measured number falls inside the stated range.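

On the second core, in this assay, methyl in place of chloro gave a 22-fold lower number from compound 3 to compound 4 (1.35 log units; beyond the scatter), the same direction as on the first core. Set side by side, the two steps do not differ by more than the scatter allows, so the change carried from one core to the other in direction and, as far as two pairs can tell, in size: the same change on two cores in this assay, a 9.0-fold lower number (0.95 log units; beyond the scatter) from compound 1 to compound 2 and a 22-fold lower number (1.35 log units; beyond the scatter) from compound 3 to compound 4, 2.5-fold (0.40 log units) apart, within the scatter of two such steps This agreement rests on just those two pairs in one cell assay, so it shows neither why methyl gives the lower number nor that the change would behave the same way on a further core.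

The compounds shown hold only chloro and methyl on this aromatic carbon, so it remains open how a hydrogen, a methoxy group, a trifluoromethyl group or a longer alkyl chain at the same place would compare with these two. From the compounds shown here alone, it is also open whether the same change would keep its direction and size in cell lines other than the one used here, and whether the lower numbers seen with methyl reflect anything more specific than the inhibition this read-out records.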